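Enantiopure versus Undefined Stereocentre in a TRPV1 Antagonist Series

A few compounds are considered here, and "the series" means these few. Any claim that something is new, unique, unknown or untested is made for them only; others in the source may bear on it.

Measured compounds:
compound 1, `Cc1nc(C(F)(F)F)ccc1CNC(=O)C(C)c1ccc(NS(C)(=O)=O)c(F)c1`, 387 nM
compound 2, `CCCCCc1nc(C(F)(F)F)ccc1CNC(=O)C(C)c1ccc(NS(C)(=O)=O)c(F)c1`, 1 nM
compound 3, `C[C@H](C(=O)NCc1ccc(C(F)(F)F)nc1C1CCC(C)(C)CC1)c1ccc(NS(C)(=O)=O)c(F)c1`, 0.3 nM

All three were tested in an assay on CHO cells for antagonist activity at transient receptor potential cation channel subfamily V member 1 (Homo sapiens), read by FLIPR and calcium flux; a higher number here means a weaker inhibitor, a lower number a stronger inhibitor. Compound 3 gives the lowest number of the three, compound 2 the next, and compound 1 the highest. Going by the values given here, the only single-point step among the measured compounds is a 390-fold lower number from compound 1 to compound 2 (2.59 log units; beyond the scatter), a large move.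

Compound 4, `CC(C(=O)NCc1ccc(C(F)(F)F)nc1C1CCC(C)(C)CC1)c1ccc(NS(C)(=O)=O)c(F)c1`, keeps every atom and bond of compound 3; the difference is the two compounds have the same atoms and bonds; at least one stereo element is drawn with a configuration in one of them and without one in the other: 1 of 1 stereo elements differ; a stereocentre at a saturated chain carbon is drawn S in compound 3 and without a configuration in compound 4. Among the compounds with values here, no measured step concerns a stereocentre; the step from compound 1 to compound 2 changes a substituent and so does not bear on this question. With no pairing of a defined and an undefined configuration among the measured compounds, the estimate rests on compound 3 alone. A sample drawn without a configuration is expected to give a number equal to or somewhat higher than compound 3, so the expected step is a 2.0-fold higher number from compound 3 to compound 4 (0.30 log units; within the scatter), at most a little beyond the scatter. Compound 4 is therefore estimated at 0.6 nM, within a range from 0.25 nM to 1.5 nM.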

Compound 4, inhibition constant: 0.4 nM
Compound 4: the middle estimate sits 1.5-fold (0.18 log units) above what was measured; low and high end bracket the measured number.
By their numbers in this assay, from the lowest: compounds 3 and 4 (each within the scatter of the next); then compound 2; then compound 1.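

Going by these compounds alone, the step of a 1.3-fold higher number from compound 3 to compound 4 (0.12 log units; within the scatter) lies within the scatter, so in this assay the form drawn S and the sample drawn without a configuration cannot be told apart, and the one structural difference behind this comparison is this: the fact that one of compounds 3 and 4 is drawn with a defined configuration and the other without, at the place where they differ Compound 4 also links the 4,4-dimethylcyclohexyl group directly to the earlier compounds: in place of pentyl it gives a 2.5-fold lower number from compound 2 to compound 4 (0.40 log units; beyond the scatter), a modest move beyond the scatter, and in place of methyl it gives a 970-fold lower number from compound 1 to compound 4 (2.99 log units; beyond the scatter), a large one. These two steps compare samples that are all drawn without a configuration at the stereocentre, a like-for-like reading that compound 3 could not provide.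

From the compounds shown here alone, how the R form behaves on its own remains open, as a drawing without a configuration does not tell what mixture of forms a sample holds. Also open, going by these compounds, is how an unsubstituted cyclohexyl or a phenyl group would compare in place of the 4,4-dimethylcyclohexyl group.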